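A Smaller Carbamoyl Group in Place of Compound 2's Substituent

The compounds below may be only part of what the source reports. "The series", "measured", "known", "first", "only" and "open" are said of these compounds alone.

Compound 2 `[O-][n+]1onc2ccc(COc3ccccc3/C=N\NC(=S)Nc3ccccc3)cc21` gives > 200 uM in an ADME assay on cells (Erythrocyte, Homo sapiens), read by spectrophotometry and hemolysis, with a stated time of 24 h (a lower number here means a stronger inhibitor, a higher number a weaker inhibitor), which is a limit of the assay and not a number. In this assay the related compound 1 `NC(=S)N/N=C\c1ccccc1OCc1ccc2no[n+]([O-])c2c1` gives 189 uM. Compound 3 `NC(=O)N/N=C\c1ccccc1OCc1ccc2no[n+]([O-])c2c1` differs from compound 2 by a group of 3 heavy atoms (1 carbon, 1 nitrogen, 1 oxygen; no ring) in place of a group of 9 heavy atoms (7 carbon, 1 nitrogen, 1 sulfur; one six-membered aromatic ring of carbon only), on an amine nitrogen. Like compound 1, it carries no phenyl group. Within the data shown here, the one measured step bearing on this change is an at least 1.0-fold higher number from compound 1 to compound 2 (0.02 log units; that floor lies within the scatter), so no shift beyond the scatter is expected. The expected change is a number no higher from compound 2 to compound 3 (the limit leaves the size open). For compound 3 the estimated value is 200 uM, with an expected range from 120 uM to 330 uM.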

Compound 3, concentration for 50% inhibition: > 100 uM
Compound 3: a limit, no number; the forecaster's own chance of this, stated with the estimate: 60%; the middle value lies beyond the limit too.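

Compound 3 gives > 100 uM, which is a limit of the assay and not a number, so its steps from compound 1 and from compound 2 cannot be read. The compounds shown leave open how the carbamoyl group in compound 3 compares with the groups it replaces in compound 1 and compound 2 in this assay.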